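The compounds below may be only part of what the source reports. "The series", "measured", "known", "first", "only" and "open" are said of these compounds alone.

In an in vivo ADME assay on the whole organism (strain Sprague-Dawley) for pharmacokinetics, with Rattus norvegicus as the target, at a dose of 5 mg/kg by the oral route (a lower number here means that a smaller share of the oral dose reaches the circulation, a higher number that a larger share of the oral dose reaches the circulation), the two compounds measured so far give the following:

Compound 2, `CCCCCOC(=O)N1CCN(C(=O)[C@H](CCC(=O)O)NC(=O)c2nc(-c3ccccc3)cc(N3CCC(CN)CC3)n2)CC1`, gives 1%.
Compound 1, `CCCCCOC(=O)N1CCN(C(=O)[C@H](CCC(=O)O)NC(=O)c2cc(N3CCC(C(=O)N4CCCC4)CC3)nc(-c3ccccc3)n2)CC1`, gives 13%.

Compound 2 thus stands at the bottom of these two numbers; its nearest neighbour, compound 1, lies higher by more than the usual scatter. The two differ in several places at once, so no single step can be read off between them. Compound 3, `CCCCCOC(=O)N1CCN(C(=O)[C@H](CCC(=O)O)NC(=O)c2nc(-c3ccccc3)cc(N3CCC(COC)CC3)n2)CC1`, is not yet measured. It differs from compound 2 in one place: methoxy in place of amino on a saturated chain carbon bound to a saturated ring carbon. Within the data shown here, no pair of measured compounds shows this same change, so its size cannot be taken from the present numbers. Starting from compound 2 with 1% there is little room downward, and the expected step in this assay is a small rise, a number 4 percentage points higher from compound 2 to compound 3 (within the scatter), which may still fall within the scatter. Compound 3 is therefore estimated at 5%, with a range from 1% to 20%.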

Compound 3, oral bioavailability: 6%
Estimate against measurement, compound 3: 1 percentage points below; measured number inside the range.
By their numbers in this assay, from the lowest: compounds 2, 3 and 1 (each within the scatter of the next, the first and the last beyond it).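

In this assay, methoxy in place of amino on a saturated chain carbon bound to a saturated ring carbon gives a number 5 percentage points higher from compound 2 to compound 3 (within the scatter). Among these compounds, this is the first change at this position that can be read on its own, and it shows that the amino group, with its hydrogen-bond donor, can be replaced by methoxy, which has none, without a shift in oral bioavailability that stands clear of the scatter. No measurement available here explains this result.

As far as these compounds go, it remains open whether a hydroxyl group, an ethoxy group or a carboxylic acid on this chain carbon would give a step beyond the scatter. From the compounds shown here alone, it also remains open whether the same change from amino to methoxy would give a step of similar size on a different core.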